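A few compounds are considered here, and "the series" means these few. Any claim that something is new, unique, unknown or untested is made for them only; others in the source may bear on it.

Measured so far in a functional assay on MCF7 cells (Homo sapiens) for antiproliferative activity; on this read-out lower numbers stand for stronger inhibition and higher numbers for weaker inhibition
compound 1 (`O=C(Nc1ccc(O)c2c(=O)cc(-c3ccccc3Cl)oc12)c1ccccc1`): 7100 nM
compound 2 (`O=C(Nc1ccc(O)c2c(=O)cc(-c3ccccc3Cl)oc12)c1ccc(Cl)c(Cl)c1`): 15000 nM

Compound 1 holds the lower of the two numbers, which makes it the stronger inhibitor of this pair. Among the measured compounds shown here, the only measured step is a 2.1-fold higher number from compound 1 to compound 2 (0.32 log units; beyond the scatter) and it puts 3,4-dichlorophenyl in place of phenyl on a carbonyl carbon.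

Compound 3 (`O=c1cc(-c2ccccc2Cl)oc2c(N3CCCC3)ccc(O)c12`) has no number yet. It keeps the core of compound 1 but carries pyrrolidin-1-yl in place of benzamido on an aromatic carbon, para to a hydroxy group (pyrrolidin-1-yl in place of benzamido on an aromatic carbon). This change goes further than the measured one: the whole benzamido leaves, whereas compound 2 keeps a substituted form of it. The modest size of a 2.1-fold higher number from compound 1 to compound 2 (0.32 log units; beyond the scatter) is therefore only a weak guide to the step in this assay and it points in no firm direction. The best guess is no step beyond the scatter, with a wide range left open. An estimated 1.4-fold higher number from compound 1 to compound 3 (0.15 log units; within the scatter) is what this amounts to. For compound 3 the estimated value is 10000 nM with an expected range from 3000 nM to 35000 nM at the upper end.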

Compound 3, half-maximal inhibitory concentration: 20000 nM
For compound 3 the middle estimate is 2.0-fold (0.30 log units) below the measured one; the range from low to high includes it.
By their numbers in this assay, from the lowest: compound 1; then compounds 2 and 3 (each within the scatter of the next).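

In this assay, replacing the whole benzamido with the smaller pyrrolidin-1-yl gives a 2.8-fold higher number from compound 1 to compound 3 (0.45 log units; beyond the scatter), so a measurable antiproliferative effect remains even without the amide and its aromatic ring. The earlier step, a 2.1-fold higher number from compound 1 to compound 2 (0.32 log units; beyond the scatter), changed only the outer ring of the benzamido, whereas this one shows that replacing the entire group also gives a modest rise, leaving compound 1 with the lowest number of the three. The swap changes several things at once, including the ring type, the size of the group and the loss of a hydrogen-bond donor, and nothing available here shows which of these matters for the result.

The compounds shown leave open whether the amide or the phenyl ring counts for more at this position, a question that acetamido, which keeps the amide without the phenyl, could help to separate from the effect of a saturated ring such as morpholin-4-yl. Also open, as far as these compounds go, is whether any group here, such as a free amino group, could improve on the number of compound 1, 7100 nM.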